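A few compounds are considered here, and "the series" means these few. Any claim that something is new, unique, unknown or untested is made for them only; others in the source may bear on it.

In a functional assay on HeLa cells (Homo sapiens) for cytotoxicity (a higher number here means that more compound is tolerated, a lower number that less compound is tolerated), compound 1 `CCCCCCCCOC(=O)C(O)Cn1cnc2c(N)ncnc21` gives 100 ug/mL, the lowest of the two numbers measured here. Compound 2 `CC(C)CCOC(=O)C(O)Cn1cnc2c(N)ncnc21` gives 400 ug/mL, and the step of a 4.0-fold higher number from compound 1 to compound 2 (0.60 log units; beyond the scatter) came with isopropyl in place of hexyl on a saturated chain carbon. Compound 3 `CCC(C)OC(=O)C(O)Cn1cnc2c(N)ncnc21` reached only the limit of the assay, > 400 ug/mL. The step of an at least 4.0-fold higher number from compound 1 to compound 3 (0.60 log units; beyond the scatter) points the same way, with sec-butyl in place of octyl. Compound 4 `Nc1ncnc2c1ncn2CC(O)C(=O)OCc1ccco1` differs from compound 1 by furan-2-yl in place of heptyl on a saturated chain carbon bound to an oxygen next to a carbonyl group, again a smaller group on the ester. Both shortenings measured so far raised the tolerated amount by a modest step, as the steps of a 4.0-fold higher number from compound 1 to compound 2 (0.60 log units; beyond the scatter) and an at least 4.0-fold higher number from compound 1 to compound 3 (0.60 log units; beyond the scatter) show. Compound 4 is therefore expected to show a 2.5-fold higher number from compound 1 to compound 4 (0.40 log units; beyond the scatter), an estimated 250 ug/mL within a range of 100 ug/mL to 400 ug/mL.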

Compound 4, minimum cytotoxic concentration: 40 ug/mL
The estimate for compound 4 lay 6.3-fold (0.80 log units) above the measured number, and the stated range ends above it.
By their numbers in this assay, from the lowest: compound 4; then compound 1; then compound 2.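

On this ester, a smaller group does not always mean more compound is tolerated: replacing octyl with (furan-2-yl)methyl gives a 2.5-fold lower number from compound 1 to compound 4 (0.40 log units; beyond the scatter), the opposite direction to the earlier shortenings in this assay. Against the branched chains the drop is larger, with a 10-fold lower number from compound 2 to compound 4 (1.00 log units; beyond the scatter) and an at least 10-fold lower number from compound 3 to compound 4 (1.00 log units; beyond the scatter). The second of these steps gives only a minimum size, as compound 3 stands at a limit: the limit of > 400 ug/mL in this assay, at which 1 of the 4 values shown sits.

Still open, going by these compounds, is whether a benzyl ester would give the same drop, or whether it is particular to the furan ring with its oxygen.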